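Three Thiourea Analogues Measured for Liver-Cell Toxicity, a Fourth Awaited

This account rests on a few compounds, and the source may have more. Where it says the series, first, only, none or still open, it means among the compounds named here.

Measured so far:
compound 1 `O=C(NC(=S)N1CCc2c(OCCCCCOc3ccc(Cl)cc3)cccc21)c1ccc([N+](=O)[O-])cc1` gives 13600 nM
compound 2 `O=C(NC(=S)N1CCc2c(OCCCCCOc3ccc(Cl)cc3)cccc21)c1ccc(F)cc1` gives 31100 nM
compound 3 `O=C(NC(=S)N1CCc2c(OCCCCCOc3ccc(Cl)cc3)cccc21)c1ccc(C(F)(F)F)cc1` gives 32700 nM

These numbers come from an ADME assay on Huh-7 cells (Homo sapiens) for cytotoxicity; on this read-out lower numbers stand for higher toxicity in this test and higher numbers for lower toxicity in this test. Compound 3 holds the highest number of the three, but one of its gaps is small (a 1.1-fold higher number from compound 2 to compound 3 (0.02 log units; within the scatter)), while the other is larger (a 2.4-fold higher number from compound 1 to compound 3 (0.38 log units; beyond the scatter)). Compound 4 `O=C(CCc1ccccc1)NC(=S)N1CCc2c(OCCCCCOc3ccc(Cl)cc3)cccc21` is the next step: phenethyl in place of 4-(trifluoromethyl)phenyl on a carbonyl carbon. Going by the values given here, no measured step swaps the whole aromatic group for a chain, so nothing bears on it directly; the known swaps, a 2.3-fold higher number from compound 1 to compound 2 (0.36 log units; beyond the scatter) and a 2.4-fold higher number from compound 1 to compound 3 (0.38 log units; beyond the scatter), were modest. A step in this assay near or within the scatter is therefore expected, a 1.1-fold lower number from compound 3 to compound 4 (0.04 log units; within the scatter). The estimate for compound 4 is 30000 nM, with a range from 10000 nM to 70000 nM.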

Compound 4, half-maximal cytotoxic concentration: > 50000 nM
Compound 4: only a limit was reported; the forecaster's own chance of this, stated with the estimate: 20%; middle value at least 1.6-fold (0.22 log units) from the limit.
By their numbers in this assay, from the lowest: compound 1; then compounds 2 and 3 (each within the scatter of the next). At a limit, above all of these: compound 4.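

In this assay compound 4 gives > 50000 nM, which is a limit of the assay and not a number. Until now only the group on the aromatic ring had changed; here phenethyl replaces the whole aryl group on the carbonyl carbon without any sign of higher toxicity in this test. The swap gives an at least 3.6-fold higher number from compound 1 to compound 4 (0.56 log units; beyond the scatter), while the floors of an at least 1.6-fold higher number from compound 2 to compound 4 (0.20 log units; that floor lies within the scatter) and an at least 1.5-fold higher number from compound 3 to compound 4 (0.18 log units; that floor lies within the scatter) are too low to separate these compounds.

On these data alone, how far compound 4 really lies from compounds 2 and 3 remains open. So does the effect of a benzyl group, a longer chain or an amine on this carbonyl carbon.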